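The source may report more compounds than this note shows. Statements on the series, on what has been measured and on what is new or still open speak of the compounds shown alone.

In an assay on CHO cells for antagonist activity at transient receptor potential cation channel subfamily V member 1 (Homo sapiens), read by FLIPR (a lower number here means a stronger inhibitor, a higher number a weaker inhibitor), compound 1 `CC(C(=O)NCc1ccc(C(F)(F)F)cc1N1CCCC1)c1ccc(NS(C)(=O)=O)c(F)c1` gives 2.3 nM. In this assay compound 2 `CC(C(=O)NCc1ccc(C(F)(F)F)cc1N1CCN(c2ccccc2)CC1)c1ccc(NS(C)(=O)=O)c(F)c1` gives 2 nM.

Going by the values given here, compound 2 holds the lowest of the two numbers seen so far, but the only step joining the pair, a 1.2-fold lower number from compound 1 to compound 2 (0.06 log units; within the scatter), lies within the scatter, so the two compounds cannot be placed in any order. Compound 3 `CC(C)CCOc1cc(C(F)(F)F)ccc1CNC(=O)C(C)c1ccc(NS(C)(=O)=O)c(F)c1` is not yet measured. It differs from compound 2 in one place: isopentyloxy in place of 4-phenylpiperazin-1-yl on an aromatic carbon. Among the compounds with values here, the one measured step at this position, a 1.2-fold lower number from compound 1 to compound 2 (0.06 log units; within the scatter), exchanged one nitrogen-containing ring for another and left the number essentially unchanged. Within the data shown here, it bears on the new change only loosely, since here a group with two rings gives way to one with no ring and an oxygen, an exchange that no measured step covers. The account therefore expects a small step at most, leaning toward a somewhat higher number for compound 3, with a wide range to reflect the missing precedent. Compound 3 is expected to give about 5 nM in this assay, between 1.5 nM and 20 nM. That estimate amounts to a 2.5-fold higher number from compound 2 to compound 3 (0.40 log units; beyond the scatter), an expectation rather than a measurement.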

Compound 3, inhibition constant: 0.5 nM
The estimate for compound 3 lay 10-fold (1.00 log units) above the measured number, and the stated range ends above it.
By their numbers in this assay, from the lowest: compound 3; then compounds 2 and 1 (each within the scatter of the next).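

At this position, on an aromatic carbon ortho to a large group and meta to a trifluoromethyl group, the earlier pair had shown only that pyrrolidin-1-yl and 4-phenylpiperazin-1-yl give numbers within the scatter of each other; compound 3 shows that the position can respond in this assay, with a 4.0-fold lower number from compound 2 to compound 3 (0.60 log units; beyond the scatter) when isopentyloxy replaces 4-phenylpiperazin-1-yl. The exchange for pyrrolidin-1-yl gives a 4.6-fold lower number from compound 1 to compound 3 (0.66 log units; beyond the scatter), so the ring-free isopentyloxy group gives a lower number than both ring-bearing groups, whichever of the two is the starting point. Nothing measured here accounts for this gain, and the exchange alters the ring content and the linking atom together.

As far as these compounds go, whether the oxygen or the branched chain carries the step stays open: an isopentylamino group at this position would test the linking atom, while a methoxy group or an unbranched pentyloxy chain would test the length and branching of the chain. From the compounds shown here alone, it is also open whether isopentyloxy would hold its advantage over pyrrolidin-1-yl and 4-phenylpiperazin-1-yl with another group in place of the trifluoromethyl group, such as a tert-butyl group.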